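Fluoro in place of nitro: expectation for compound 3

The compounds below may be only part of what the source reports. "The series", "measured", "known", "first", "only" and "open" are said of these compounds alone.

For the measured compounds named here, in an ADME assay on the whole organism (muscle tissue) for activation, with Mus musculus as the target, in the rotarod test, with a stated time of 30 min (a higher number here means that more compound is needed for the effect, a lower number that less compound is needed), compound 2 (`O=C1NC(=O)N(/N=C/c2ccc(-c3ccc([N+](=O)[O-])cc3)o2)C1O`) gives 171 mg/kg as the only actual number so far. Compound 1 (`CC(=O)Nc1ccc(-c2ccc(/C=N/N3C(=O)NC(=O)C3O)o2)cc1`) gives > 1000 mg/kg in this assay and this is a limit of the assay, not a number.

Compound 3 (`O=C1NC(=O)N(/N=C/c2ccc(-c3ccc(F)cc3)o2)C1O`) carries fluoro in place of nitro on an aromatic carbon, para to a large group (fluoro in place of nitro on an aromatic carbon). Going by the values given here, only one measured step bears on this carbon: nitro in place of acetamido gave an at least 5.8-fold lower number from compound 1 to compound 2 (0.76 log units; beyond the scatter) and so the group here can shift the number. That step gives no reading for fluoro, so the range stays wide. With nitro leaving, a modest move to a higher number is expected, and the estimated size is a 2.3-fold higher number from compound 2 to compound 3 (0.37 log units; beyond the scatter) in this assay as a smaller move than that step. For compound 3 the expected value is 400 mg/kg in this assay (estimated range 130 mg/kg to 1200 mg/kg).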

Compound 3, dose for half-maximal effect: 240 mg/kg
Compound 3: middle estimate off by 1.7-fold (0.22 log units), on the high side; measured number inside the range.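

In this assay, fluoro in place of nitro on this aromatic carbon gives a 1.4-fold higher number from compound 2 to compound 3 (0.15 log units; within the scatter), so these two groups are not separated here. Nitro is therefore not needed for a measured number at this carbon: fluoro in place of acetamido gives an at least 4.1-fold lower number from compound 1 to compound 3 (0.61 log units; beyond the scatter), so the earlier separation also appears with a group that has a single heavy atom. Compound 1 gives > 1000 mg/kg, which is a limit of the assay and not a number: the limit of > 1000 mg/kg in this assay, at which 1 of the 3 values shown sits.

As far as these compounds go, it remains open how an amine, a methoxy group or a carboxylic acid on this aromatic carbon would read, and whether any group here separates from both nitro and fluoro. From the compounds shown here alone, it is also open whether the reading at this carbon would hold with a change elsewhere on the shared core.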